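The source may hold more compounds than are shown below. What is called first, only, known or untested is meant among the compounds shown, and "the series" means these compounds.

Measured in an ADME assay on Vero 76 cells (Chlorocebus sabaeus) for cytotoxicity, read by crystal violet staining, with a stated time of 96 h; a lower number here means that less compound is tolerated, a higher number that more compound is tolerated:
- compound 1 `O=C(NC(=S)Nc1cccc(C(F)(F)F)c1)c1ccccc1`: > 100000 nM (a limit)
- compound 2 `FC(F)(F)c1cccc(NC(=S)Nc2ccc(Cl)cc2)c1`: 11000 nM
- compound 3 `CC(=O)NC(=S)Nc1cccc(C(F)(F)F)c1`: > 100000 nM (a limit)

Compound 3 has no exact number in this assay, only a limit of > 100000 nM. That is the limit of > 100000 nM in this assay, at which 2 of the 3 values shown sit.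

The next compound, compound 4 `Fc1ccccc1NC(=S)Nc1cccc(C(F)(F)F)c1`, carries 2-fluorophenyl in place of acetyl on an amide-type nitrogen.

The closest measured change, acetyl in place of 4-chlorophenyl on an amide-type nitrogen, is an at least 9.0-fold higher number from compound 2 to compound 3 (0.95 log units; beyond the scatter). The other measured change, a step that the two limits leave unreadable from compound 1 to compound 3, offers no size to work with. Compound 4 puts an aromatic ring back on that nitrogen, so it resembles compound 2, which gives 11000 nM. However, 2-fluorophenyl itself has not been measured here, so this comparison is only a guide.

A move to a lower number is therefore expected, roughly reversing the earlier step, and is estimated as an at least 5.0-fold lower number from compound 3 to compound 4 (0.69 log units; beyond the scatter). For compound 4 the estimated value is 20000 nM, with an expected range of 7000 nM to 70000 nM.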

Compound 4, half-maximal cytotoxic concentration: 64000 nM
For compound 4 the middle estimate is 3.2-fold (0.51 log units) below the measured one; low and high end bracket the measured number.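

In this assay, the choice of ring on this amide-type nitrogen clearly matters: replacing 4-chlorophenyl with 2-fluorophenyl gives a 5.8-fold higher number from compound 2 to compound 4 (0.76 log units; beyond the scatter), so carrying an aromatic ring there does not by itself set how much compound is tolerated. Replacing acetyl with 2-fluorophenyl gives an at least 1.5-fold lower number from compound 3 to compound 4 (0.19 log units; that floor lies within the scatter), so this change is not firmly shown to lower the number. That step can be stated only as a floor because compound 3 has a limit rather than an exact number: the limit of > 100000 nM in this assay, at which 2 of the 4 values shown sit.

Compounds 2 and 4 differ in both the halogen and its place on the ring, so the effect of each remains unseparated. As far as these compounds go, it also remains open how this number would respond to an amine, a carboxylic acid or a longer carbon chain on the same nitrogen.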